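The source may hold more compounds than are shown below. What is called first, only, known or untested is meant among the compounds shown, and "the series" means these compounds.

Measured so far in a physicochemical assay for solubility, at pH 7.4; a lower number here means a less soluble compound, a higher number a more soluble compound:
- compound 1 `O=P(O)(O)OCc1nc(Nc2ccc(C(F)(F)F)cc2)c2ccc(-c3ncccc3C(F)(F)F)cc2n1`: > 138 ug/mL, a limit of the assay and not a number
- compound 2 `O=C(O)COCc1nc(Nc2ccc(C(F)(F)F)cc2)c2ccc(-c3ncccc3C(F)(F)F)cc2n1`: 125 ug/mL
- compound 3 `OCCCc1nc(Nc2ccc(C(F)(F)F)cc2)c2ccc(-c3ncccc3C(F)(F)F)cc2n1`: 0.06 ug/mL

Compound 3 stands lowest of the numbers at 0.06 ug/mL, and the nearest number belongs to compound 2, at 125 ug/mL. The next compound, compound 4 `O=C(O)CCc1nc(Nc2ccc(C(F)(F)F)cc2)c2ccc(-c3ncccc3C(F)(F)F)cc2n1`, differs from compound 3 by carboxy in place of hydroxymethyl on a saturated chain carbon, two bonds along the chain from an aromatic carbon.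

The step that bears most on this is a 2100-fold lower number from compound 2 to compound 3 (3.32 log units; beyond the scatter), with 2-hydroxyethyl in place of carboxymethoxy. The step of an at least 2300-fold lower number from compound 1 to compound 3 (3.36 log units; beyond the scatter) is similarly large, while an at least 1.1-fold lower number from compound 1 to compound 2 (0.04 log units; that floor lies within the scatter) shows no separation. Read in reverse, the step to compound 3 from compound 2 suggests that a large rise in this assay should be expected here, perhaps somewhat short of its full size.

Compound 4 is estimated at 60 ug/mL, with an expected range from 15 ug/mL to 140 ug/mL. This estimate means an expected 1000-fold higher number from compound 3 to compound 4 (3.00 log units; beyond the scatter).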

Compound 4, solubility: 125 ug/mL
Beside the measured number, compound 4's estimate is 2.1-fold (0.32 log units) below it, within the range that was stated.
By their numbers in this assay, from the lowest: compound 3; then compounds 2 and 4 (each within the scatter of the next). At a limit, above all of these: compound 1.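

In this assay, among these compounds, the single change of hydroxymethyl to carboxy on a saturated chain carbon, two bonds along the chain from an aromatic carbon, gives a 2100-fold higher number from compound 3 to compound 4 (3.32 log units; beyond the scatter). Carboxymethyl in place of carboxymethoxy gives no change at the digits printed from compound 2 to compound 4 (within the scatter), so the large earlier gap to compound 3 follows the carboxy group at the chain end and not the make-up of the chain that carries it. The remaining step, an at least 1.1-fold lower number from compound 1 to compound 4 (0.04 log units; that floor lies within the scatter), rests on a limit of the assay and not a number, so it separates nothing: the limit of > 138 ug/mL in this assay, at which 1 of the 4 values shown sits.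

The compounds shown leave open whether an amine or a primary amide at the chain end would match the carboxylic acid in this assay. They also leave open whether a longer chain ending in a carboxylic acid would hold the same number.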